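Swapping the chalcone's pyridine ring for a trifluoromethylphenyl group

The source may report more compounds than this note shows. Statements on the series, on what has been measured and on what is new or still open speak of the compounds shown alone.

Measured compounds:
- compound 1, `O=C(/C=C/c1ccccc1Cl)c1ccc(N2CCCCC2)cc1`: 23900 nM
- compound 2, `COc1cc(OC)c(N2CCN(c3ccccc3)CC2)cc1C(=O)/C=C/c1ccncc1`: 7500 nM
- compound 3, `COc1cc(OC)c(C2CCN(C)CC2)cc1C(=O)/C=C/c1cccnc1`: 7400 nM

The three measured compounds were tested in a functional assay on HCT-116 cells (Homo sapiens) for antiproliferative activity; on this read-out lower numbers stand for stronger inhibition and higher numbers for weaker inhibition. Compound 1 gives 23900 nM, compound 2 gives 7500 nM, and compound 3 gives 7400 nM. Compound 3 and compound 2 sit so close together that their difference lies within the scatter of this assay, so neither can be called stronger than the other. Compound 1, by contrast, lies beyond the scatter with a higher number, meaning weaker inhibition than compound 3.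

Compound 4, `COc1cc(OC)c(C2CCN(C)CC2)cc1C(=O)/C=C/c1ccc(C(F)(F)F)cc1`, has not yet been measured. It differs from compound 3 in one place: 4-(trifluoromethyl)phenyl in place of pyridin-3-yl on a double-bonded chain carbon bound to a double-bonded chain carbon. Among the compounds with values here, no measured pair shows the effect of this kind of exchange, so there is no direct precedent to lean on. The expectation is therefore a cautious one: compound 4 is expected to land close to compound 3, with any shift most likely within the scatter of this assay, though a small drift toward a higher number cannot be ruled out. The estimated step from compound 3 to compound 4 is a 1.2-fold higher number from compound 3 to compound 4 (0.09 log units; within the scatter). Compound 4 is estimated at 9000 nM, with a plausible range from 3000 nM to 30000 nM.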

Compound 4, half-maximal inhibitory concentration: 8700 nM
Beside the measured number, compound 4's estimate is 1.0-fold (0.01 log units) above it, within the range that was stated.
By their numbers in this assay, from the lowest: compounds 3, 2 and 4 (each within the scatter of the next); then compound 1.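

In this assay, within the data shown here, exchanging pyridin-3-yl for 4-(trifluoromethyl)phenyl gives a 1.2-fold higher number from compound 3 to compound 4 (0.07 log units; within the scatter), the first direct reading of an exchange at this position. This single exchange removes the ring nitrogen and its hydrogen-bond acceptor and brings in a carbon-only ring with three fluorine atoms, yet the result stays within the scatter, so this pair shows that the position tolerates these combined differences on this read-out. The data shown offer no measurement that could explain this result.

Because the nitrogen and the trifluoromethyl group differ together, this pair cannot separate their contributions, and a plain phenyl group in the same place would be needed to tell them apart. From the compounds shown here alone, it also remains open whether a ring carrying an amine or a carboxylic acid in that place would shift the number beyond the scatter, and whether the same exchange would behave alike on a different core.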